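Dichlorophenyl to methylphenyl at the nitrogen: what to expect

The compounds below may be only part of what the source reports. "The series", "measured", "known", "first", "only" and "open" are said of these compounds alone.

compound 1 `Cc1nc(Nc2ccccc2)sc1C(=O)/C=C/c1ccc(Cl)cc1`: > 25000 nM
compound 2 `COc1cc(/C=C/C(=O)c2sc(Nc3ccc(Cl)c(Cl)c3)nc2C)cc(OC)c1OC`: > 25000 nM

Of the compounds shown here, two have so far been tested in a functional assay on Bel-7402 cells (Homo sapiens) for cytotoxicity, read by MTT assay; a higher number here means a weaker inhibitor, a lower number a stronger inhibitor. Compound 1 `Cc1nc(Nc2ccccc2)sc1C(=O)/C=C/c1ccc(Cl)cc1` gives > 25000 nM, which is a limit of the assay and not a number. Compound 2 `COc1cc(/C=C/C(=O)c2sc(Nc3ccc(Cl)c(Cl)c3)nc2C)cc(OC)c1OC` gives > 25000 nM, again a limit rather than a measured value. Both results sit at the limit of > 25000 nM in this assay, at which 2 of the 2 values shown sit, so compound 2 stands nowhere in particular among the numbers shown, only at the edge of what this assay reports. Within the data shown here, no step between measured compounds can be drawn: compound 1 and compound 2 differ in more than one place, and their two values show only that each is a limit.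

Compound 3 `COc1cc(/C=C/C(=O)c2sc(Nc3cccc(C)c3)nc2C)cc(OC)c1OC` is not yet measured. It differs from compound 2 by 3-methylphenyl in place of 3,4-dichlorophenyl on a nitrogen on an aromatic ring. Among the measured compounds shown here, with no measured step to lean on, and with compound 2 itself at a limit, the expectation for this change is no movement beyond the usual scatter in either direction. The expected step in this assay is a step that the limit leaves unreadable from compound 2 to compound 3, essentially none. Compound 3 is therefore estimated at 30000 nM, within a range from 8000 nM to 120000 nM, and most likely this assay will once more report only a limit for it.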

Compound 3, half-maximal inhibitory concentration: > 25000 nM
Compound 3 ended at the assay's limit; the forecaster's own chance of this, stated with the estimate: 70%; the middle value is on the limit's open side.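

In this assay compound 3 gives > 25000 nM, a limit of the assay and not a number. Compound 2 also sits at a limit, so no step can be read between compound 2 and compound 3: the limit of > 25000 nM in this assay, at which 3 of the 3 values shown sit. The compounds shown leave open whether 3-methylphenyl and 3,4-dichlorophenyl on this nitrogen differ at all in this assay.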